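The compounds below may be only part of what the source reports. "The series", "measured", "known", "first", "only" and "open" are said of these compounds alone.

Of the compounds shown here, three sharing one core have been read in a functional assay on HeLa cells (Homo sapiens) for inhibition, read by sulforhodamine B assay, with a stated time of 74 h; a higher number here means a weaker inhibitor, a lower number a stronger inhibitor. Compound 1 `Cc1ccc(S(=O)(=O)N2C(=O)COC23C=CC(=O)C=C3)cc1` gives 180 nM, and compound 2 `CS(=O)(=O)N1C(=O)COC12C=CC(=O)C=C2` gives 7530 nM. Compound 3 `O=C1C=CC2(C=C1)OCC(=O)N2S(=O)(=O)c1ccccc1` gives > 10000 nM, which is a limit of the assay and not a number.

Hydrogen in place of methyl on an aromatic carbon brought an at least 55-fold higher number from compound 1 to compound 3 (1.74 log units; beyond the scatter). Methyl in place of 4-methylphenyl on a sulfonyl sulfur brought a 42-fold higher number from compound 1 to compound 2 (1.62 log units; beyond the scatter), while phenyl in place of methyl on a sulfonyl sulfur brought an at least 1.3-fold higher number from compound 2 to compound 3 (0.12 log units; that floor lies within the scatter).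

Compound 4 `O=C1C=CC2(C=C1)OCC(=O)N2S(=O)(=O)c1ccc([N+](=O)[O-])cc1` has nitro in place of hydrogen on an aromatic carbon, para to a large group: nitro in place of hydrogen on an aromatic carbon. Going by the values given here, the step of an at least 55-fold higher number from compound 1 to compound 3 (1.74 log units; beyond the scatter) bears most directly, since it too changes a group at an aromatic carbon, although no nitro compound has yet been measured. A large move toward a lower number is therefore expected in this assay, with wide uncertainty. The expected change is an at least 8.3-fold lower number from compound 3 to compound 4 (0.92 log units; beyond the scatter). For compound 4 the estimate is 1200 nM, within an expected range from 150 nM to 10000 nM.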

Compound 4, half-maximal inhibitory concentration: > 10000 nM
Compound 4: only a limit was reported; the forecaster's own chance of this, stated with the estimate: 20%; middle value at least 8.3-fold (0.92 log units) away from the limit.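

In this assay compound 4 gives > 10000 nM, which is a limit of the assay and not a number. On the aromatic carbon para to a large group, nitro therefore does not recover the reading of compound 1: nitro in place of methyl gives an at least 55-fold higher number from compound 1 to compound 4 (1.74 log units; beyond the scatter), so among the three groups shown at this position, methyl alone gives a value inside the assay's range. Any step from compound 3 to compound 4 cannot be read, since both compounds rest on the same limit: the limit of > 10000 nM in this assay, at which 2 of the 4 values shown sit.

The compounds shown leave open whether the low number of compound 1 is particular to methyl or would also appear with a longer chain such as ethyl, or with an amine or methoxy at this carbon. They also leave open how far compound 3 and compound 4 lie from each other beyond the limit.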